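The compounds below may be only part of what the source reports. "The series", "measured", "known", "first", "only" and "open" are said of these compounds alone.

Of the compounds shown here, three sharing one core have been measured. Compound 1 `O=C(CCSc1nc2cc(Cl)ccc2o1)N1CCC1` carries azetidin-1-yl on the carbonyl carbon, compound 2 `CCN(CC)C(=O)CCSc1nc2cc(Cl)ccc2o1` carries diethylamino there, and compound 3 `CN1CCN(C(=O)CCSc2nc3cc(Cl)ccc3o2)CC1` carries 4-methylpiperazin-1-yl. In an ADME assay on microsomes from liver (Homo sapiens) for metabolic stability, read by LC-MS, using NADPH, with a stated time of 45 min, tested at 0.5 uM (on this read-out higher numbers stand for fast clearance and lower numbers for slow clearance), compound 1 gives 3.7 mL/min/g, compound 2 gives 5.9 mL/min/g, and compound 3 gives 1.5 mL/min/g. Compound 3 stands lowest of the three: the step of a 2.5-fold lower number from compound 1 to compound 3 (0.39 log units; beyond the scatter) and the step of a 3.9-fold lower number from compound 2 to compound 3 (0.59 log units; beyond the scatter) both lie beyond the scatter, while the step of a 1.6-fold higher number from compound 1 to compound 2 (0.20 log units; within the scatter) does not.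

Compound 4 `O=C(CCSc1nc2cc(Cl)ccc2o1)N1CCS(=O)(=O)C1` is not yet measured. It differs from compound 3 only at the carbonyl carbon: 1,1-dioxo-1,3-thiazolidin-3-yl in place of 4-methylpiperazin-1-yl on a carbonyl carbon

The two steps that bear on this change are the ones into compound 3, a 2.5-fold lower number from compound 1 to compound 3 (0.39 log units; beyond the scatter) and a 3.9-fold lower number from compound 2 to compound 3 (0.59 log units; beyond the scatter), both modest changes at the same carbonyl carbon. On that basis the expected step for compound 4 is a 1.9-fold higher number from compound 3 to compound 4 (0.27 log units; within the scatter), a modest rise back toward the values of compound 1 and compound 2. The estimate for compound 4 in this assay is therefore 2.8 mL/min/g, with a range from 1.2 mL/min/g to 6.5 mL/min/g.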

Compound 4, intrinsic clearance in a liver preparation (reported as CLH), per the amount of preparation that the assay uses: 1.7 mL/min/g
For compound 4 the middle estimate is 1.6-fold (0.22 log units) above the measured one, within the range that was stated.
By their numbers in this assay, from the lowest: compounds 3 and 4 (each within the scatter of the next); then compounds 1 and 2 (each within the scatter of the next).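

In this assay, with a 1.1-fold higher number from compound 3 to compound 4 (0.05 log units; within the scatter), the 1,1-dioxo-1,3-thiazolidin-3-yl group cannot be told apart from 4-methylpiperazin-1-yl at this carbonyl carbon, so the low end of the series is not confined to a single group, even though the entering ring is five-membered rather than six-membered and holds sulfur where the leaving ring holds a second nitrogen. Compound 4 also stands clear of the other two amides, with a 3.5-fold lower number from compound 2 to compound 4 (0.54 log units; beyond the scatter) and a 2.2-fold lower number from compound 1 to compound 4 (0.34 log units; beyond the scatter), both beyond the scatter. Among these four compounds, the two groups with two hetero atoms in the ring therefore sit apart from azetidin-1-yl and diethylamino, and none of the four goes against this split.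

Nothing available here accounts for the match between the two groups or for their separation from the other two. From the compounds shown here alone, it remains open whether morpholin-4-yl, with oxygen as its second ring hetero atom, would join compound 3 and compound 4, and whether piperidin-1-yl, a six-membered ring with only its nitrogen, would instead fall with compound 1 and compound 2.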